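The compounds below may be only part of what the source reports. "The series", "measured", "known", "first", "only" and "open" are said of these compounds alone.

Measured so far in an ADME assay on HEK293 cells (Homo sapiens) for antiproliferative activity, read by MTT assay, with a stated time of 24 h; a higher number here means a weaker inhibitor, a lower number a stronger inhibitor: compound 1 `COc1cc(/C=C/C(=O)c2cc(-c3cc(OC)c(OC)c(OC)c3)n3nc(-c4ccccc4)cc3n2)cc(OC)c1OC` gives 41000 nM; compound 2 `COc1ccc(-c2cc(C(=O)/C=C/c3cc(OC)c(OC)c(OC)c3)nc3cc(-c4ccccc4)nn23)cc1OC` gives 46800 nM; compound 3 `COc1ccc(-c2cc(/C=C/C(=O)c3ccccc3)nc3cc(-c4ccccc4)nn23)cc1` gives 53200 nM.

Among these three numbers compound 2 stands second highest. Its nearest neighbour is compound 3, and its furthest is compound 1; both gaps lie within the scatter, so the three measured compounds cannot be told apart in this assay.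

Compound 4 `COc1ccc(/C=C/C(=O)c2cc(-c3ccc(OC)c(OC)c3)n3nc(-c4ccccc4)cc3n2)cc1` is not yet measured. It differs from compound 2 in one place: 4-methoxyphenyl in place of 3,4,5-trimethoxyphenyl on a double-bonded chain carbon bound to a double-bonded chain carbon

Among the measured compounds shown here, only one measured step is available to judge this change, and it is a 1.1-fold higher number from compound 1 to compound 2 (0.06 log units; within the scatter). That step removes a single methoxy group from an aromatic ring and leaves the number essentially unchanged. Compound 3 carries neither trimethoxyphenyl nor methoxyphenyl on the chain, yet it differs from compound 2 in more than one place, so its value can only be set beside that of compound 2, where the two are within the scatter of each other.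

The step from compound 2 to compound 4 is therefore expected to be small, amounting to a 1.0-fold higher number from compound 2 to compound 4 (0.01 log units; within the scatter), with no direction beyond the scatter. For compound 4 the estimate in this assay is 48000 nM, within the range 24000 nM to 96000 nM.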

Compound 4, half-maximal inhibitory concentration: 50700 nM
Estimate against measurement, compound 4: 1.1-fold (0.02 log units) below; low and high end bracket the measured number.
By their numbers in this assay, from the lowest: compounds 1, 2, 4 and 3 (each within the scatter of the next).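

Replacing 3,4,5-trimethoxyphenyl with 4-methoxyphenyl on a double-bonded chain carbon bound to a double-bonded chain carbon gives, in this assay, a 1.1-fold higher number from compound 2 to compound 4 (0.03 log units; within the scatter). Among the compounds shown here, this is the first direct look at this position, since the earlier measured step changed a methoxy group elsewhere in the molecule, and it shows that going from 12 heavy atoms to 8 and from 3 hydrogen-bond acceptors to 1 in this group leaves the number within the scatter. No measurement is available that could explain why this change makes so little difference.

As far as these compounds go, the two groups compared at this position are both methoxy-bearing phenyl rings, so it remains open whether a quite different group there, such as an amine or a carboxylic acid on the ring, would move the number beyond the scatter. This is also a single pair, and it cannot show whether the same swap would be as quiet if the other aromatic ring on the shared core carried different groups.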